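The compounds below may be only part of what the source reports. "The series", "measured", "known", "first", "only" and "open" are said of these compounds alone.

Measured so far in a functional assay on L1210 cells (Mus musculus) for antiproliferative activity; on this read-out lower numbers stand for stronger inhibition and higher numbers for weaker inhibition:
Compound 1, `c1ccc(CSc2nc3cnsc3[nH]2)cc1`: compound 1 gives 300 nM.
Compound 2, `CSc1nc2cnsc2n1[C@H]1C[C@H](O)[C@@H](CO)O1`: compound 2 gives only a limit of the assay, > 100000 nM.
Compound 3, `Cc1nsc2c1nc(SCc1ccccc1)n2[C@H]1C[C@H](O)[C@@H](CO)O1`: compound 3 likewise gives only a limit, > 100000 nM.

Compound 3 therefore stands not at a number but at the ceiling of this assay; that ceiling is the limit of > 100000 nM in this assay, at which 2 of the 3 values shown sit, and compound 2 shares it. Within the data shown here, compound 1 is the only member with a measured number, and it carries neither the sugar nor the methyl on the five-membered ring. Among the measured compounds shown here, it differs from compound 3 in more than one place, so the two values show only that the sugar-free member is measurable and the two sugar-bearing members are not.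

Compound 4, `OC[C@H]1O[C@@H](n2c(SCc3ccccc3)nc3cnsc32)C[C@@H]1O`, is not yet measured. It differs from compound 3 by hydrogen in place of methyl on an aromatic carbon; the methyl leaves and a hydrogen enters on the aromatic carbon of the five-membered aromatic ring with one nitrogen and one sulfur. The sugar and the benzylthio group of compound 3 remain. For the measured compounds named here, no measured step of this kind exists in the set. The step from compound 3 to compound 4 is expected to be a number no higher from compound 3 to compound 4 (the limit leaves the size open), that is, no change beyond the scatter, with compound 4 most likely remaining at the ceiling. Compound 4 is estimated at 100000 nM, within 20000 nM to 500000 nM.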

Compound 4, half-maximal inhibitory concentration: 8000 nM
Compound 4: the middle estimate sits 13-fold (1.10 log units) above what was measured; the whole stated range lies above it.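

In this assay, hydrogen in place of methyl on the aromatic carbon of the five-membered aromatic ring with one nitrogen and one sulfur gives an at least 12-fold lower number from compound 3 to compound 4 (1.09 log units; beyond the scatter), so this position decides whether a sugar-bearing member with the benzylthio group gives a measurable number at all. With that hydrogen in place, phenyl in place of hydrogen on the saturated chain carbon bound to a sulfur gives an at least 12-fold lower number from compound 2 to compound 4 (1.09 log units; beyond the scatter), so the phenyl also counts, a point that compounds 2 and 3 could not show while both sat at a limit. The sugar remains costly but does not abolish activity: 4-hydroxy-5-(hydroxymethyl)oxolan-2-yl in place of hydrogen on the aromatic nitrogen gives a 27-fold higher number from compound 1 to compound 4 (1.43 log units; beyond the scatter).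

On these data alone, the first two steps start from limits and not from numbers, so their true size stays open: the limit of > 100000 nM in this assay, at which 2 of the 4 values shown sit. Also open is whether methyl on the same aromatic carbon of compound 1 would carry a similar cost, and whether a chlorine or an amine there would behave like hydrogen or like methyl.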